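This account rests on a few compounds, and the source may have more. Where it says the series, first, only, none or still open, it means among the compounds named here.

Working notes on the series. Within the data shown here, the shared core, seen in compound 3 `Cc1ccc(Nc2cc(-c3ccccc3)oc(=O)c2)cc1`, carries a substituted amine that is the only point of change across the set. Among the measured compounds shown here, in a functional assay on KB cells (Homo sapiens) for cytotoxicity, read by MTT assay, with a stated time of 72 h (on this read-out higher numbers stand for an effect only at larger amounts of compound and lower numbers for an effect already at smaller amounts), compound 3 gives 0.064 uM, the lowest of the two numbers known; compound 2 `O=c1cc(Nc2ccccc2)cc(-c2ccccc2)o1` gives 0.13 uM, and the gap is a 2.0-fold lower number from compound 2 to compound 3 (0.31 log units; beyond the scatter). Compound 1 `O=c1cc(NC2CC2)cc(-c2ccccc2)o1` reaches only a limit of the assay, > 30 uM, as noted under (the limit of > 30 uM in this assay, at which 1 of the 3 values shown sits). From that limit to the aromatic amines the steps are large: an at least 230-fold lower number from compound 1 to compound 2 (2.36 log units; beyond the scatter) and an at least 460-fold lower number from compound 1 to compound 3 (2.67 log units; beyond the scatter).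

Compound 4 `O=c1cc(NC2CCCCC2)cc(-c2ccccc2)o1` is not yet measured. It differs from compound 3 in cyclohexyl in place of 4-methylphenyl on a nitrogen on an aromatic ring. This runs the measured steps backwards: an aromatic ring on the nitrogen gives way to a saturated one, and the steps of an at least 230-fold lower number from compound 1 to compound 2 (2.36 log units; beyond the scatter) and an at least 460-fold lower number from compound 1 to compound 3 (2.67 log units; beyond the scatter) both point to a large rise in number when the saturated ring is present. The cyclohexyl ring is larger than the cyclopropyl of compound 1, so the whole of that loss need not return, and the expected step is a 160-fold higher number from compound 3 to compound 4 (2.19 log units; beyond the scatter). Compound 4 is therefore estimated at 10 uM, with a range from 1 uM to 30 uM, and a real chance that only a limit is reported.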

Compound 4, concentration for half-maximal effect: 16 uM
Compound 4: middle estimate off by 1.6-fold (0.20 log units), on the low side, and the stated range covers the measured number.
By their numbers in this assay, from the lowest: compound 3; then compound 2; then compound 4. At a limit, above all of these: compound 1.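

In this assay, the cost of losing the aromatic ring on the nitrogen now has a measured size rather than a bound: a 250-fold higher number from compound 3 to compound 4 (2.40 log units; beyond the scatter), and a 120-fold higher number from compound 2 to compound 4 (2.09 log units; beyond the scatter), the latter pair keeping a six-membered carbon ring and differing only in whether it is aromatic. Among the saturated rings, size gives no clear separation, with an at least 1.8-fold lower number from compound 1 to compound 4 (0.27 log units; that floor lies within the scatter). The value of compound 1 is a limit, not a number: the limit of > 30 uM in this assay, at which 1 of the 4 values shown sits.

The compounds shown leave open whether aromaticity must sit directly on the nitrogen, as a benzyl group on the nitrogen would test. Also open, going by these compounds, is how far the low numbers of compound 2 and compound 3 survive a ring carrying a carboxylic acid, an amine or a methoxy group in place of the methyl.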